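Aryl swap on the shared core: clearance notes

The source may hold more compounds than are shown below. What is called first, only, known or untested is meant among the compounds shown, and "the series" means these compounds.

Measured in an ADME assay (liver) for metabolic stability, with Liver microsome (Rattus norvegicus) as the target, using microsomes and NADPH, with a stated time of 30 min, tested at 1 uM; a lower number here means slower removal, a higher number faster removal of the compound:
compound 1, `CCn1cc(-c2cc(C(O)(C(F)(F)F)C(F)(F)F)cnc2N2CCN(S(=O)(=O)c3ccc(N)nc3)CC2)cn1`: 194 mL.min-1.g-1
compound 2, `Nc1ccc(S(=O)(=O)N2CCN(c3ncc(C(O)(C(F)(F)F)C(F)(F)F)cc3-c3cnccc3F)CC2)cn1`: 22 mL.min-1.g-1

Within the data shown here, compound 2 has the lowest number of the two; the only neighbour, compound 1, sits higher, and the step of an 8.8-fold lower number from compound 1 to compound 2 (0.95 log units; beyond the scatter) is beyond the scatter.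

Compound 3, `Nc1ccc(S(=O)(=O)N2CCN(c3ncc(C(O)(C(F)(F)F)C(F)(F)F)cc3-c3cc4ccccc4[nH]3)CC2)cn1`, is not yet measured in this assay. It differs from compound 2 in one place: 1H-indol-2-yl in place of 4-fluoropyridin-3-yl on an aromatic carbon. Among the measured compounds shown here, the only measured step that bears on this is an 8.8-fold lower number from compound 1 to compound 2 (0.95 log units; beyond the scatter), which was also an exchange of the aromatic group on that same carbon and moved the number a good deal; the present exchange takes the series to a third group of a different size, so the size and direction of its step cannot be read off that one comparison with confidence. Given that the sole precedent for a change at this carbon was well beyond the scatter, a step beyond the scatter is expected here too, and on balance an upward one, back toward compound 1. Compound 3 is therefore expected at 70 mL.min-1.g-1, within 25 mL.min-1.g-1 to 200 mL.min-1.g-1. This estimate means an expected step of a 3.2-fold higher number from compound 2 to compound 3 (0.50 log units; beyond the scatter).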

Compound 3, intrinsic clearance in microsomes: 146 mL.min-1.g-1
Compound 3: the middle estimate sits 2.1-fold (0.32 log units) below what was measured, and the stated range covers the measured number.
By their numbers in this assay, from the lowest: compound 2; then compounds 3 and 1 (each within the scatter of the next).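

In this assay, replacing 4-fluoropyridin-3-yl with the larger 1H-indol-2-yl on this aromatic carbon gives a 6.6-fold higher number from compound 2 to compound 3 (0.82 log units; beyond the scatter), so a second exchange at this position also moves the number beyond the scatter, this time upward. Compound 3 and compound 1 cannot be told apart, with a 1.3-fold lower number from compound 1 to compound 3 (0.12 log units; within the scatter), so 1H-indol-2-yl and 1-ethyl-1H-pyrazol-4-yl give matching clearance, and among these three groups only the 4-fluoropyridin-3-yl of compound 2 stands apart. No supporting measurement is available to explain why the numbers fall this way.

The compounds shown leave open whether the low clearance of compound 2 goes with the ring nitrogen, the fluorine or their combination, a question that an unsubstituted pyridyl group and a fluorophenyl group on the same carbon would help to separate. As far as these compounds go, it is also open whether the high clearance of compound 3 stays the same with a methyl group on the indole nitrogen, or with a smaller pyrrole in place of the indole.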